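This account rests on a few compounds, and the source may have more. Where it says the series, first, only, none or still open, it means among the compounds named here.

In a functional assay on UACC-62 cells (Homo sapiens) for antiproliferative activity, read by sulforhodamine B assay, with a stated time of 48 h (a higher number here means a weaker inhibitor, a lower number a stronger inhibitor), compound 1 `O=C(NCCCNc1cc(-c2cn(-c3ccccc3)nc2-c2cccc(O)c2)ccn1)Nc1ccc(F)cc1` gives 3140 nM and compound 2 `O=C(NCCCNc1cc(-c2cn(-c3ccccc3)nc2-c2cccc(O)c2)ccn1)Nc1cccc(C(F)(F)F)c1` gives 4410 nM. For the measured compounds named here, these are the only two numbers so far, and they lie within the scatter of each other, so the data cannot separate compound 1 from its one neighbour.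

Compound 3 `COc1cccc(-c2nn(-c3ccccc3)cc2-c2ccnc(NCCCNC(=O)Nc3ccc(F)cc3)c2)c1` keeps the core of compound 1 but turns hydroxy to methoxy, a change of 3-hydroxyphenyl to 3-methoxyphenyl: methyl in place of hydrogen on an oxygen on an aromatic ring.

Going by the values given here, the single measured step, a 1.4-fold higher number from compound 1 to compound 2 (0.15 log units; within the scatter), replaces 4-fluorophenyl with 3-(trifluoromethyl)phenyl on an amide-type nitrogen. It does not touch this oxygen, so it bears only loosely on the new change. No direction can be argued, and no shift beyond the scatter is firmly expected in this assay. The expected step is a 1.1-fold higher number from compound 1 to compound 3 (0.05 log units; within the scatter). Compound 3 is estimated at 3500 nM, with an expected range from 1300 nM to 10000 nM.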

Compound 3, half-maximal inhibitory concentration: 7570 nM
Estimate against measurement, compound 3: 2.2-fold (0.34 log units) below, and the stated range covers the measured number.
By their numbers in this assay, from the lowest: compounds 1, 2 and 3 (each within the scatter of the next, the first and the last beyond it).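

Putting a methyl on the oxygen, which turns 3-hydroxyphenyl into 3-methoxyphenyl, gives a 2.4-fold higher number from compound 1 to compound 3 (0.38 log units; beyond the scatter) in this assay. This is the only step shown that passes the usual scatter, so the hydroxy hydrogen on this aromatic ring matters more to the number than the swap on the far end of the urea-bearing chain did, although the move towards a weaker inhibitor is modest. No measurement at hand offers an explanation for this shift.

From the compounds shown here alone, one replacement cannot tell whether the loss comes from gaining the methyl or from losing the hydrogen, and whether the same step would hold with the 3-(trifluoromethyl)phenyl group of compound 2 also stays open. An amine or a fluorine in place of the hydroxy, or a longer ethoxy group on the same oxygen, would test this position further.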